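Fluorine on the anilide ring: an expected small lipophilicity shift

The compounds below may be only part of what the source reports. "The series", "measured", "known", "first", "only" and "open" are said of these compounds alone.

Measured so far:
Compound 1, `COc1ccc2nc(C)cc(NC(=O)C(=O)Nc3cc(C)cc(C)c3)c2c1`: 6.47
Compound 2, `COc1ccc2nc(C)cc(OCC(=O)Nc3cc(C)ccc3C)c2c1`: 5.05

Two compounds sharing the same quinoline-free description, the shared core, have been measured in a physicochemical assay for lipophilicity, read by HPLC, in phosphate buffer, measured as chromatographic lipophilicity, at pH 7.4; on this read-out lower numbers stand for lower lipophilicity and higher numbers for higher lipophilicity. Compound 1 gives 6.47 in this assay. Compound 2 gives 5.05, the lower of the two numbers, and the gap to compound 1 lies beyond the scatter. Among the compounds with values here, no single-point step between these two is known, because they differ in more than one place.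

Compound 3, `COc1ccc2nc(C)cc(OCC(=O)Nc3cc(C)c(F)c(C)c3)c2c1`, is built from compound 2 by one change: 4-fluoro-3,5-dimethylphenyl in place of 2,5-dimethylphenyl on an amide-type nitrogen. The only difference is therefore the pattern of groups on that aromatic ring, with one fluorine entering.

The step from compound 2 to compound 3 is expected to be small and upward, a number 0.25 log units higher from compound 2 to compound 3 (within the scatter), perhaps not beyond the scatter. Compound 3 is estimated at 5.3, with a range from 4.9 to 5.7.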

Compound 3, distribution coefficient: 5.5
Compound 3: the middle estimate sits 0.20 log units below what was measured, within the range that was stated.
By their numbers in this assay, from the lowest: compound 2; then compound 3; then compound 1.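

At this amide-type nitrogen, in this assay the swap of 2,5-dimethylphenyl for 4-fluoro-3,5-dimethylphenyl gives a number 0.45 log units higher from compound 2 to compound 3 (beyond the scatter) with the rest of the molecule unchanged. Within the data shown here, this is the first step that can be read at a single place, and it shows that the aromatic ring on that nitrogen alone can move the read-out by more than the usual scatter. No independent measurement is available to explain the size of this step.

The change moves the methyl groups and adds a fluorine at once, so the compounds shown cannot divide the step between those two parts. A close partner such as 4-chloro-3,5-dimethylphenyl or plain phenyl on the same nitrogen would show how far the step depends on the fluorine itself.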